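Propyl chain variations on the shared core in KB cells

A few compounds are considered here, and "the series" means these few. Any claim that something is new, unique, unknown or untested is made for them only; others in the source may bear on it.

Compound 1 `C=CCn1c(N)c(C#N)c2c(N)ncnc21` – compound 1 gives > 100000 nM in a functional assay on KB cells (Homo sapiens) for inhibition (a higher number here means a weaker inhibitor, a lower number a stronger inhibitor), a limit of the assay and not a number.
Compound 2 `COCCOCn1c(N)c(C#N)c2c(N)ncnc21` – compound 2 gives 210000 nM in this assay.
Compound 3 `CCCn1c(N)c(C#N)c2c(N)ncnc21` – compound 3 gives 15000 nM in this assay.

Compound 3 holds the lowest of the two numbers shown; the nearest is compound 2 at a gap of a 14-fold lower number from compound 2 to compound 3 (1.15 log units; beyond the scatter), and compound 1 sits at the limit (the limit of > 100000 nM in this assay, at which 1 of the 3 values shown sits), so its step to compound 3 reads only as an at least 6.6-fold lower number from compound 1 to compound 3 (0.82 log units; beyond the scatter). Both steps concern the group on the saturated chain carbon bound to the aromatic nitrogen, and both end at the ethyl of compound 3.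

Compound 4 `Cc1cccc(Cn2c(N)c(C#N)c3c(N)ncnc32)c1` carries the change (3-methylphenyl in place of ethyl on a saturated chain carbon bound to an aromatic nitrogen). The change enters an aromatic ring where the two measured steps only exchanged chains, so neither step maps onto it directly; they show that the group at this position moves the number by a modest to large amount. Compound 4 is therefore expected near compound 3, with a small step of a 1.7-fold lower number from compound 3 to compound 4 (0.22 log units; within the scatter) in this assay, direction uncertain. The estimate for compound 4 is 9000 nM, within 1500 nM to 50000 nM.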

Compound 4, half-maximal inhibitory concentration: > 100000 nM
Compound 4: a limit, no number (the forecaster's own chance of this, stated with the estimate: 5%); middle value at least 11-fold (1.04 log units) away from the limit.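

In this assay compound 4 gives a limit of the assay and not a number: the limit of > 100000 nM in this assay, at which 2 of the 4 values shown sit. Putting 3-methylphenyl in place of ethyl gives an at least 6.6-fold higher number from compound 3 to compound 4 (0.82 log units; beyond the scatter), so this position, so far seen with chains only, now shows that a group carrying an aromatic ring does not keep the level of compound 3. The steps to compound 4 from compound 1 and from compound 2 cannot be read, and compound 3 stays the lowest of the series, with steps beyond the scatter to all three others.

From the compounds shown here alone, it remains open whether the ring itself or its methyl carries this step, which a plain phenyl in the same place would separate. Also open, going by these compounds, is how a longer chain such as butyl, or a chain ending in an amine, would compare with compound 3.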